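The source may hold more compounds than are shown below. What is called first, only, known or untested is meant among the compounds shown, and "the series" means these compounds.

In a functional assay on MGC-803 cells (Homo sapiens) for antiproliferative activity, read by MTT assay, with a stated time of 72 h (on this read-out lower numbers stand for stronger inhibition and higher numbers for weaker inhibition), compound 1 `CCCSc1nc(N/N=C(\C)c2ccc(OC)cc2)c2nnn(Cc3ccccc3)c2n1` gives 44300 nM, and compound 3 `CCCSc1nc(N/N=C(\C)c2ccccc2O)c2nnn(Cc3ccc(F)cc3)c2n1` gives 11000 nM. For compound 2 `CCCSc1nc(N/N=C/c2cccc(Cl)c2)c2nnn(Cc3ccccc3)c2n1` the result in this assay is only a limit, > 64000 nM. That places compound 2 at the limit of > 64000 nM in this assay, at which 1 of the 3 values shown sits, so no number marks its strength. Compound 4 `CCCSc1nc(N/N=C/c2ccccc2F)c2nnn(Cc3ccccc3)c2n1` has not yet been tested in this assay. It differs from compound 2 in one place: 2-fluorophenyl in place of 3-chlorophenyl on a carbon with a double bond to nitrogen. Among the measured compounds shown here, no measured pair with this kind of change is available, so the change is expected to bring nothing beyond the usual scatter of this assay, leaving compound 4 weak. The step expected in this assay is an at least 1.1-fold lower number from compound 2 to compound 4 (0.06 log units; that floor lies within the scatter). Compound 4 is therefore estimated at 55000 nM, between 20000 nM and 150000 nM, and a further limit is quite possible.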

Compound 4, half-maximal inhibitory concentration: > 64000 nM
Compound 4: no number, only a limit; the forecaster's own chance of this, stated with the estimate: 50%; at least 1.1-fold (0.06 log units) between middle value and limit.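

Compound 2 and compound 4 both give only a limit in this assay, so no step can be read between them: the limit of > 64000 nM in this assay, at which 2 of the 4 values shown sit.

The compounds shown leave open whether 2-fluorophenyl in place of 3-chlorophenyl changes the strength of inhibition at all.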